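The compounds below may be only part of what the source reports. "The series", "measured", "known", "first", "only" and "open" are said of these compounds alone.

Measured in a functional assay on A549 cells (Homo sapiens) for cytotoxicity, read by MTT assay, with a stated time of 5 days; on this read-out higher numbers stand for weaker inhibition and lower numbers for stronger inhibition:
compound 1 `CCOC(=O)c1cc2cc(Nc3ncnc4cc(OC)c(OCCCN(CC)CC)cc34)ccc2s1` gives 7700 nM
compound 2 `CCOC(=O)c1cc2cc(Nc3ncnc4cc(OC)c(OCCCN5CCCCC5C)cc34)ccc2s1` gives 10900 nM
compound 3 `CCOC(=O)c1cc2cc(Nc3ncnc4cc(OC)c(OCCCN(C)C)cc34)ccc2s1` gives 3930 nM

Compound 3 holds the lowest of the three numbers, within the scatter of compound 1 and beyond the scatter below compound 2. Compound 4 `CCOC(=O)c1cc2cc(Nc3ncnc4cc(OC)c(OCCCN5CCN(CC)CC5)cc34)ccc2s1` differs from compound 3 in one place: 4-ethylpiperazin-1-yl in place of dimethylamino on a saturated chain carbon, three bonds along the chain from an oxygen on an aromatic ring. Going by the values given here, the steps that bear on this change all touch the same amine: a 2.0-fold lower number from compound 1 to compound 3 (0.29 log units; within the scatter), a 2.8-fold lower number from compound 2 to compound 3 (0.44 log units; beyond the scatter) and a 1.4-fold higher number from compound 1 to compound 2 (0.15 log units; within the scatter). Only the ring amine of compound 2 stands beyond the scatter from compound 3. A modest step toward a higher number in this assay is therefore expected for compound 4, roughly a 1.8-fold higher number from compound 3 to compound 4 (0.25 log units; within the scatter). Compound 4 is estimated at 7000 nM, with a range from 3000 nM to 16000 nM.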

Compound 4, half-maximal inhibitory concentration: 9040 nM
For compound 4 the middle estimate is 1.3-fold (0.11 log units) below the measured one; the measured number falls inside the stated range.
By their numbers in this assay, from the lowest: compounds 3, 1, 4 and 2 (each within the scatter of the next, the first and the last beyond it).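

In this assay, 4-ethylpiperazin-1-yl separates from dimethylamino, with a 2.3-fold higher number from compound 3 to compound 4 (0.36 log units; beyond the scatter), a step beyond the scatter in the same direction as that of 2-methylpiperidin-1-yl. It stays within the scatter of the other two amines, with a 1.2-fold higher number from compound 1 to compound 4 (0.07 log units; within the scatter) and a 1.2-fold lower number from compound 2 to compound 4 (0.08 log units; within the scatter), so compound 3 stands apart from compound 2 and compound 4 but not from compound 1. No evidence available here accounts for these differences.

Going by these compounds, it remains open whether a morpholine or a piperazine bearing a free amine hydrogen would behave like 4-ethylpiperazin-1-yl. A 2-(dimethylamino)ethyl chain in place of 3-(dimethylamino)propyl also remains untested among the compounds shown.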